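The compounds below may be only part of what the source reports. "The series", "measured", "known", "first", "only" and "open" are said of these compounds alone.

Compound 1 `CC(C)=CCC/C(C)=C/CC/C(C)=C/CC[C@@H]1[C@@]2(C)CC/C(=N\OCc3cn(-c4cccc(Br)c4)nn3)C(C)(C)[C@@H]2CC[C@@]1(C)O` — 39800 nM
Compound 2 `CC(C)=CCC/C(C)=C/CC/C(C)=C/CC[C@@H]1[C@@]2(C)C/C(=C\c3ccc(OCc4cn(-c5ccccc5)nn4)cc3)C(=O)C(C)(C)[C@@H]2CC[C@@]1(C)O` — 126000 nM

Of the compounds shown here, two built on a shared core have been tested in a functional assay on HepG2 cells (Homo sapiens) for cytotoxicity, read by MTT assay, with a stated time of 48 h; on this read-out lower numbers stand for stronger inhibition and higher numbers for weaker inhibition. Compound 1 gives 39800 nM in this assay, and compound 2 gives 126000 nM. Going by the values given here, compound 2 therefore carries the higher of the two numbers; the gap to compound 1, its only neighbour, lies beyond the usual scatter.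

Compound 3 `CC(C)=CCC/C(C)=C/CC/C(C)=C/CC[C@@H]1[C@@]2(C)C/C(=C\c3ccc(OCc4cn(-c5cccc([N+](=O)[O-])c5)nn4)cc3)C(=O)C(C)(C)[C@@H]2CC[C@@]1(C)O` has not yet been measured. It differs from compound 2 by nitro in place of hydrogen on an aromatic carbon, set meta to a large group on the phenyl of compound 2. Among the compounds with values here, no pair of measured compounds shows a change of this kind, so there is no precedent to lean on. The account expects a step from compound 2 to compound 3 in this assay of a 1.3-fold lower number from compound 2 to compound 3 (0.10 log units; within the scatter), a change not beyond the scatter and of no firm direction. Compound 3 is accordingly estimated at 100000 nM, within a range from 40000 nM to 300000 nM.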

Compound 3, half-maximal inhibitory concentration: 117000 nM
Compound 3: middle estimate off by 1.2-fold (0.07 log units), on the low side; low and high end bracket the measured number.
By their numbers in this assay, from the lowest: compound 1; then compounds 3 and 2 (each within the scatter of the next).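

Replacing hydrogen with nitro on the aromatic carbon meta to a large group, which turns phenyl into 3-nitrophenyl, gives in this assay a 1.1-fold lower number from compound 2 to compound 3 (0.03 log units; within the scatter), a step that stays within the usual scatter. Going by these compounds alone, it is the first single-place comparison available, and it shows that this position accepts nitro, with its three heavy atoms, without a change that can be told apart from repeat measurement. Nothing measured here offers an explanation for this outcome.

The compounds shown leave open whether an amine, a carboxylic acid or a methoxy group on this same carbon would give a step beyond the scatter. They also leave open whether nitro on another carbon of this phenyl would behave as it does here.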